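Nitro for methoxy on the shared hydrazone core

This account rests on a few compounds, and the source may have more. Where it says the series, first, only, none or still open, it means among the compounds named here.

Measured compounds:
compound 1 `c1ccc(NN=C(c2nc3ccccc3[nH]2)c2nc3ccccc3[nH]2)cc1` — 81900 nM
compound 2 `COc1ccc(NN=C(c2nc3ccccc3[nH]2)c2nc3ccccc3[nH]2)cc1` — 114000 nM
compound 3 `Clc1ccc(NN=C(c2nc3ccccc3[nH]2)c2nc3ccccc3[nH]2)cc1` — 114000 nM

The three compounds were tested in a functional assay on HT-29 cells (Homo sapiens) for cytotoxicity, read by MTT assay, with a stated time of 72 h; on this read-out higher numbers stand for weaker inhibition and lower numbers for stronger inhibition. Compound 1 gives 81900 nM, compound 2 gives 114000 nM and compound 3 gives 114000 nM. Compound 2 stands level with compound 3 and within the scatter of compound 1: the step of a 1.4-fold higher number from compound 1 to compound 2 (0.14 log units; within the scatter), the step of a 1.4-fold higher number from compound 1 to compound 3 (0.14 log units; within the scatter) and the step of no change at the digits printed from compound 2 to compound 3 (within the scatter) all lie inside the usual spread of repeated measurements.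

Compound 4 `O=[N+]([O-])c1ccc(NN=C(c2nc3ccccc3[nH]2)c2nc3ccccc3[nH]2)cc1` differs from compound 2 in one place: nitro in place of methoxy on an aromatic carbon. Among the compounds with values here, no measured step brings a nitro group in, so the closest guide is that the three changes at this aromatic carbon — hydrogen, methoxy, chloro — left the number unchanged beyond the scatter. On that basis compound 4 is expected to stay near compound 2, with a step of a 1.1-fold lower number from compound 2 to compound 4 (0.06 log units; within the scatter) in this assay, in no direction beyond the scatter. The estimate for compound 4 is 100000 nM, with a range from 40000 nM to 250000 nM.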

Compound 4, half-maximal inhibitory concentration: 17700 nM
The estimate for compound 4 lay 5.6-fold (0.75 log units) above the measured number; measured number below the stated range.
By their numbers in this assay, from the lowest: compound 4; then compounds 1, 2 and 3 (each within the scatter of the next).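

In this assay, nitro is the only group shown at this aromatic carbon that moves the number beyond the scatter, with steps of (a 6.4-fold lower number from compound 2 to compound 4 (0.81 log units; beyond the scatter)), (a 6.4-fold lower number from compound 3 to compound 4 (0.81 log units; beyond the scatter)) and (a 4.6-fold lower number from compound 1 to compound 4 (0.67 log units; beyond the scatter)). The position is therefore not indifferent to what it carries, although hydrogen, methoxy and chloro had suggested that it might be. Compound 4 has the lowest number of the four, and all three of its steps are beyond the scatter but modest in size.

No measurement shown here accounts for why nitro alone stands apart. The compounds also leave open whether a nitrile, a trifluoromethyl group or an amine on the same carbon would follow compound 4 or stay with compounds 1, 2 and 3.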